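From Ethyl to Butyl on the Shared Core

A few compounds are considered here, and "the series" means these few. Any claim that something is new, unique, unknown or untested is made for them only; others in the source may bear on it.

In a toxicity assay on THP-1 cells (Homo sapiens) for inhibition (on this read-out lower numbers stand for higher toxicity in this test and higher numbers for lower toxicity in this test), compound 1 (`Cn1c(-c2ccccc2[N+](=O)[O-])cnc1NC(=O)c1ccc(F)cc1`) gives 31000 nM as a measured number. Compound 2 (`CCn1c(-c2ccc(OC)cc2)cnc1NC(=O)c1ccc(F)cc1`) reads > 100000 nM in this assay and this is a limit of the assay, not a number. Compound 2 therefore has no exact place on the scale and is known only from that limit.

Compound 3 (`CCCCn1c(-c2ccc(OC)cc2)cnc1NC(=O)c1ccc(F)cc1`) departs from compound 2 in one place by ethyl in place of hydrogen on a saturated chain carbon, two bonds along the chain from an aromatic nitrogen and in words this is ethyl in place of hydrogen on a saturated chain carbon, two bonds along the chain from an aromatic nitrogen, so that ethyl becomes butyl.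

For the measured compounds named here, no measured step between close relatives is available to guide this change in this assay for now. Going by the values given here, the only exact number nearby belongs to compound 1 at 31000 nM and it suggests that numbers of this size do occur here, so a small step toward lower numbers is expected, one that may stay within the scatter. The expected move is an at least 1.4-fold lower number from compound 2 to compound 3 (0.15 log units; that floor lies within the scatter) and it remains an estimate. In this assay compound 3 is estimated at 70000 nM with an expected range from 25000 nM to 200000 nM and the result may again be only a limit.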

Compound 3, half-maximal cytotoxic concentration: > 100000 nM
Compound 3: only a limit was reported; the forecaster's own chance of this, stated with the estimate: 50%; at least 1.4-fold (0.15 log units) between middle value and limit.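

In this assay compound 3 gives > 100000 nM, which is a limit of the assay, not a number. Compound 2 also stands only at a limit, so no step can be read between compound 2 and compound 3. The compounds shown leave open whether going from ethyl to butyl changes the read-out at all, as both rest on the same limit: the limit of > 100000 nM in this assay, at which 2 of the 3 values shown sit.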